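Carbonyl to hydroxy change on compound 1

The compounds below may be only part of what the source reports. "The series", "measured", "known", "first", "only" and "open" are said of these compounds alone.

- compound 1 `CCn1c(C(=O)NCCN(C)C)ccc1C(CC)(CC)c1ccc(OCC(=O)C(C)(C)C)c(C)c1` gives 2300 nM
- compound 2 `CCn1c(C(=O)NCCN)ccc1C(CC)(CC)c1ccc(OCC(=O)C(C)(C)C)c(C)c1` gives 480 nM

In a functional assay on PC-3 cells (Homo sapiens), read by MTT assay, with a stated time of 48 h (on this read-out higher numbers stand for weaker inhibition and lower numbers for stronger inhibition), compound 1 stands highest of the two, at 2300 nM. For the measured compounds named here, the only measured step, a 4.8-fold lower number from compound 1 to compound 2 (0.68 log units; beyond the scatter), puts amino in place of dimethylamino on a saturated chain carbon, two bonds along the chain from an amide-type nitrogen.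

Compound 3 `CCn1c(C(=O)NCCN(C)C)ccc1C(CC)(CC)c1ccc(OCC(O)C(C)(C)C)c(C)c1` keeps that dimethylamino and changes elsewhere: 1-hydroxy-2,2-dimethylpropyl in place of (tert-butyl)carbonyl on a saturated chain carbon bound to an oxygen on an aromatic ring. Here 1-hydroxy-2,2-dimethylpropyl stands in place of (tert-butyl)carbonyl on a saturated chain carbon bound to an oxygen on an aromatic ring. Going by the values given here, the measured step lies at another place, and no measured pair tests this change. No direction is therefore expected in this assay, and the range stays wide.

The expected result is a 1.2-fold lower number from compound 1 to compound 3 (0.06 log units; within the scatter). Compound 3 is estimated at 2000 nM, with an expected range of 700 nM to 5500 nM.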

Compound 3, half-maximal inhibitory concentration: 1630 nM
Compound 3: middle estimate off by 1.2-fold (0.09 log units), on the high side; the range from low to high includes it.
By their numbers in this assay, from the lowest: compound 2; then compounds 3 and 1 (each within the scatter of the next).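

In this assay, for the compounds shown here, the first change at this position gives a 1.4-fold lower number from compound 1 to compound 3 (0.15 log units; within the scatter) and so stays within the scatter, with the dimethylamino chain held constant. On a saturated chain carbon bound to an oxygen on an aromatic ring, 1-hydroxy-2,2-dimethylpropyl, which brings a hydrogen-bond donor that (tert-butyl)carbonyl lacks, therefore stands in for that group without a readable shift in this cell read-out. No measurement is available that accounts for this result.

The compounds shown leave open whether the same change reads alike on the amino chain of compound 2. They also leave open how a methoxy group or an amine would read in place of the hydroxy group, and how an ethyl or isopropyl group would read in place of the tert-butyl end.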